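A few compounds are considered here, and "the series" means these few. Any claim that something is new, unique, unknown or untested is made for them only; others in the source may bear on it.

Measured compounds:
compound 1, `COc1ccccc1-c1ncnn1-c1cc(OC)c(OC)c(OC)c1`: > 10000 nM
compound 2, `COc1cc(-n2ncnc2-c2ccc(F)cc2)cc(OC)c1OC`: > 10000 nM
compound 3, `COc1cc(-n2ncnc2-c2cccc(F)c2)cc(OC)c1OC`: > 10000 nM

All three were tested in a functional assay on MCF7 cells (Homo sapiens) for antiproliferative activity, read by MTT assay, with a stated time of 72 h; on this read-out higher numbers stand for weaker inhibition and lower numbers for stronger inhibition. Compound 1 gives only a limit there, > 10000 nM, and not a number. Compound 2 and compound 3 sit at the same limit (the limit of > 10000 nM in this assay, at which 3 of the 3 values shown sit), so the steps a step that the two limits leave unreadable from compound 1 to compound 2, a step that the two limits leave unreadable from compound 1 to compound 3 and a step that the two limits leave unreadable from compound 2 to compound 3 cannot be read in size or direction: the three compounds differ in the aryl group attached to the shared core, and every one of them is too weak for the assay to register.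

Compound 4, `CCOc1ccccc1-c1ncnn1-c1cc(OC)c(OC)c(OC)c1`, differs from compound 1 in a single place: methyl in place of hydrogen on a saturated chain carbon bound to an oxygen on an aromatic ring. Going by the values given here, none of the measured steps touches this place, since each of them swaps the aryl group on the core; no measured step therefore bears on this change, and no size or direction can be drawn from them. Among the compounds with values here, the only anchor is compound 1 itself, which shows no measurable inhibition. Compound 4 is therefore expected to give about 15000 nM in this assay, with a range from 5000 nM to 50000 nM. The step that the limit leaves unreadable from compound 1 to compound 4 is thus estimated to be small, and compound 4 is most likely to return only a limit as well.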

Compound 4, half-maximal inhibitory concentration: > 10000 nM
Compound 4 was reported as a limit; the forecaster's own chance of this, stated with the estimate: 80%; the middle value is on the limit's open side.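

Compound 4 gives > 10000 nM, which is a limit and not a number. Compound 1 is also only a limit, so no new step can be read: the limit of > 10000 nM in this assay, at which 4 of the 4 values shown sit. In this assay the compounds shown leave open which change on the shared core, if any, would give a measurable value.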